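From a short chain to a longer one

The compounds below may be only part of what the source reports. "The series", "measured", "known", "first", "only" and "open" are said of these compounds alone.

Values in an ADME assay on CEM-SS cells (Homo sapiens) for cytotoxicity, read by XTT assay, with a stated time of 6 days; a lower number here means that less compound is tolerated, a higher number that more compound is tolerated:
- Compound 1 `NC(=O)CCNC(=O)c1cccc(S)c1` gives > 100 uM
- Compound 2 `CCCC(=O)OCSc1ccc(OC(F)(F)F)cc1C(=O)NC(C)(C)C(N)=O` gives < 56.1 uM
- Compound 3 `CCCC(=O)OCSc1ccccc1C(=O)NCC(N)=O` gives > 100 uM

Each of these values is a limit of the assay, not a number. They gather at two limits (the limit of > 100 uM in this assay, at which 2 of the 3 values shown sit) and (the limit of < 56.1 uM in this assay, at which 1 of the 3 values shown sits). Compound 3 stands at the limit of > 100 uM and so has no exact value.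

Compound 4 `CCCC(=O)OCSc1ccccc1C(=O)NCCCC(N)=O` has 2-carbamoylethyl in place of carbamoyl on a saturated chain carbon bound to an amide-type nitrogen. Going by the values given here, no measured pair shows such a change, so the expectation in this assay is for no shift beyond the usual scatter, in either direction. The estimated step is a number no higher from compound 3 to compound 4 (the limit leaves the size open) in size. Compound 4 is expected at 100 uM, within a range of 45 uM to 200 uM, and may well be reported only as a limit.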

Compound 4, half-maximal toxic concentration: 56.6 uM
Compound 4: the middle estimate sits 1.8-fold (0.25 log units) above what was measured; the range from low to high includes it.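

With the longer chain, this assay yields the only exact number among these compounds: compound 4 gives 56.6 uM. Compound 3 has only a limit of the assay, so the size of the change cannot be fixed: the limit of > 100 uM in this assay, at which 2 of the 4 values shown sit. Going from carbamoyl to 2-carbamoylethyl at this position gives an at least 1.7-fold lower number from compound 3 to compound 4 (0.24 log units; that floor lies within the scatter), and that floor alone does not show a real change. As far as these compounds go, the true size of the step stays open. So does whether a carboxylic acid or an amine in place of the carbamoyl would move the number.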